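Swapping a Halogenated Phenyl on the Hydrazone Arm

This account rests on a few compounds, and the source may have more. Where it says the series, first, only, none or still open, it means among the compounds named here.

Compound 1 `CCCSc1nc(N/N=C/c2ccc(Cl)cc2)c2nnn(Cc3ccccc3)c2n1` was tested in a functional assay on MCF7 cells (Homo sapiens) for antiproliferative activity, read by MTT assay, with a stated time of 72 h; a higher number here means a weaker inhibitor, a lower number a stronger inhibitor. For compound 1 the assay reports only a limit, > 64000 nM, so compound 1 stands at the limit of > 64000 nM in this assay, at which 1 of the 2 values shown sits. Compound 2 `C#CCSc1nc(N/N=C/c2c(O)ccc3ccccc23)c2nnn(Cc3ccccc3)c2n1`, built on the shared core but changed in two places, gives 8970 nM in this assay. Compound 3 `CCCSc1nc(N/N=C/c2ccccc2F)c2nnn(Cc3ccccc3)c2n1` is not yet measured; it differs from compound 1 by 2-fluorophenyl in place of 4-chlorophenyl on a carbon with a double bond to nitrogen. Among the compounds with values here, with no measured step of this kind to lean on, the change is expected to stay within the scatter, a number no higher from compound 1 to compound 3 (the limit leaves the size open). Compound 3 is therefore expected to give about 64000 nM, between 20000 nM and 150000 nM, most likely again reported only as a limit.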

Compound 3, half-maximal inhibitory concentration: > 64000 nM
Compound 3 was reported as a limit (the forecaster's own chance of this, stated with the estimate: 70%); the middle value lies on the limit itself.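

Compound 1 and compound 3 are both reported only as limits, so no step between them can be read: the limit of > 64000 nM in this assay, at which 2 of the 3 values shown sit.

On these data alone, whether 2-fluorophenyl in place of 4-chlorophenyl changes activity at all in this assay stays open.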